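The source may report more compounds than this note shows. Statements on the series, on what has been measured and on what is new or still open speak of the compounds shown alone.

In an assay on lysosomes for inhibition of Maltase-glucoamylase (Homo sapiens), read by spectrophotometry, tested at 1000 uM (a higher number here means more inhibition at the concentration tested (going by the name of the read-out), a lower number less inhibition), the measured compounds stand as follows:
compound 1 `Cc1ccc([C@@H]2NC[C@H](O)[C@H]2O)cc1` gives 4.8%
compound 2 `O[C@@H]1[C@@H](O)CN[C@H]1c1ccc(F)cc1` gives 30%
compound 3 `Cc1ccc([C@H]2NC[C@@H](O)[C@@H]2O)cc1` gives 15%

Compound 3 is the second highest of the three. Its nearest neighbour is compound 1, the step being a number 10.2 percentage points higher from compound 1 to compound 3 (beyond the scatter); this rests on (the fact that compounds 1 and 3 differ only in the configuration as drawn). Compound 2 stands further off.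

Compound 4 `O[C@H]1[C@H](O)CN[C@@H]1c1ccccc1` differs from compound 3 by hydrogen in place of methyl on an aromatic carbon. Within the data shown here, the one measured step at that aromatic carbon is a number 25.2 percentage points higher from compound 1 to compound 2 (beyond the scatter), though it was seen in the mirror-image series. Taking the fluoro step as an upper bound for what replacing the methyl may do, a modest rise is expected for compound 4, a number 7 percentage points higher from compound 3 to compound 4 (within the scatter). Compound 4 is therefore estimated at 22%, within a range of 6% to 40%.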

Compound 4, a percentage reported as inhibition, at one concentration (the size of the read-out at that concentration, not a potency): 29%
Estimate against measurement, compound 4: 7 percentage points below; measured number inside the range.
By their numbers in this assay, from the lowest: compound 1; then compound 3; then compounds 4 and 2 (each within the scatter of the next).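

Hydrogen in place of methyl on the aromatic carbon gives a number a number 14 percentage points higher from compound 3 to compound 4 (beyond the scatter), so the methyl can be left out in the configuration of compound 3 without any loss of inhibition. Among these compounds, until now, the only measured change at this position was the fluoro step a number 25.2 percentage points higher from compound 1 to compound 2 (beyond the scatter), and it was seen in the mirror-image series. Both listed replacements of the methyl now raise the number, one in each series, though the two series are separate: the fact that compounds 1 and 3 differ only in the configuration as drawn

As far as these compounds go, how hydrogen and fluoro compare within a single configuration remains open. So does the outcome with chloro, methoxy or an amine at this position.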